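Compound 3 to compound 4: a new amide side chain

A few compounds are considered here, and "the series" means these few. Any claim that something is new, unique, unknown or untested is made for them only; others in the source may bear on it.

For the measured compounds named here, in a functional assay on MCF7 cells (Homo sapiens) for antiproliferative activity, read by MTT assay, with a stated time of 72 h (a lower number here means a stronger inhibitor, a higher number a weaker inhibitor), compound 3 `CCn1cc(C(CC)(CC)c2ccc(C#CC(O)(CC)CC)c(C)c2)cc1C(=O)NCC(=O)OC` gives 26500 nM, the only number so far. Compound 1 `CCn1c(C(=O)NCCC(=O)OC)ccc1C(CC)(CC)c1ccc(C#CC(O)(CC)CC)c(C)c1` reports only a limit, > 50000 nM. Compound 2 `C#CCCOC(=O)c1ccc(C(CC)(CC)c2ccc(C#CC(O)(CC)CC)c(C)c2)n1CC` likewise reports only a limit, > 50000 nM. The readings therefore consist of one number and (the limit of > 50000 nM in this assay, at which 2 of the 3 values shown sit), so the distance from compound 3 to the other two cannot be read.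

Compound 4 `CCn1cc(C(CC)(CC)c2ccc(C#CC(O)(CC)CC)c(C)c2)cc1C(=O)NCCN(C)C` keeps the shared core of compound 3 and alters the end of the amide side chain: (dimethylamino)methyl in place of methoxycarbonyl on a saturated chain carbon bound to an amide-type nitrogen. Cut one bond further out, this is ((methoxycarbonyl)methyl)carbamoyl to (2-(dimethylamino)ethyl)carbamoyl.

Going by the values given here, the only measured step at a carbonyl side chain is a step that the two limits leave unreadable from compound 1 to compound 2. It is a different exchange and offers no size to carry over. Among the compounds with values here, the sole anchor is therefore compound 3 at 26500 nM, and no step beyond the scatter is expected in this assay, with no direction favoured. A reading that returns only a limit remains possible. The expected change is a 1.0-fold lower number from compound 3 to compound 4 (0.01 log units; within the scatter). The estimate for compound 4 is 26000 nM, with an expected range of 9000 nM to 50000 nM.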

Compound 4, half-maximal inhibitory concentration: 13400 nM
The estimate for compound 4 lay 1.9-fold (0.29 log units) above the measured number, within the range that was stated.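

For the compounds shown here, compound 3 and compound 4 give the first readable step: in this assay, (dimethylamino)methyl in place of methoxycarbonyl on a saturated chain carbon bound to an amide-type nitrogen gives a 2.0-fold lower number from compound 3 to compound 4 (0.30 log units; within the scatter). At this position, then, an ester end and a dimethylamino end of similar size, each with 4 heavy atoms, cannot be told apart in this assay, even though the exchange removes both oxygen atoms and the double bond outside aromatic rings. Compound 1 and compound 2 each report a limit rather than a number, so their steps cannot be read and they add nothing on the size of this change: the limit of > 50000 nM in this assay, at which 2 of the 4 values shown sit.

From the compounds shown here alone, it remains open whether a carboxylic acid, a morpholine or a longer chain carrying the dimethylamino group at the end of this amide side chain would give a step beyond the scatter. Going by these compounds, with a single readable step, it is also open whether the same exchange would behave alike on the core of compound 1.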